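The compounds below may be only part of what the source reports. "The series", "measured", "known", "first", "only" and "open" are said of these compounds alone.

Measured compounds:
Compound 1, `CCc1ccc(N(CC2CCC2)S(=O)(=O)c2ccc3c(c2)C(=O)CC(C2CCOCC2)O3)cc1`, in a physicochemical assay for lipophilicity, at pH 7.4 (a lower number here means a more polar compound, a higher number a more lipophilic compound), gives 4.1.
Compound 2, `CCc1ccc2c(c1)CC(C)CN2S(=O)(=O)c1ccc2c(c1)C(=O)CC(C1CCOCC1)O2`, in this assay gives 3.77.
Compound 3, `CC(C)CN(c1ccc(F)cc1F)S(=O)(=O)c1ccc2c(c1)C(=O)CC(C1CCOCC1)O2`, in this assay gives 3.62.

All three share the same core, and they differ only in what sits on the sulfonamide nitrogen. Among the three numbers compound 3 has the lowest. Its nearest neighbour is compound 2, whose number is higher by an amount that lies within the usual scatter of the assay, so the two cannot be told apart with confidence. Compound 1 stands furthest away, higher by an amount that is beyond the scatter, so compound 1 is clearly the more lipophilic of that pair.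

Compound 4, `CC(C)CN(C1CCc2ccc(F)cc21)S(=O)(=O)c1ccc2c(c1)C(=O)CC(C1CCOCC1)O2`, has not yet been measured in this assay. It differs from compound 3 in one place: 6-fluoro-2,3-dihydro-1H-inden-1-yl in place of 2,4-difluorophenyl on a sulfonamide nitrogen. Among the compounds with values here, no measured pair in this set shows the same change, so there is no directly comparable step to lean on.

The expectation for compound 4 is a modest rise, with the step from compound 3 to compound 4 estimated at a number 0.28 log units higher from compound 3 to compound 4 (within the scatter), a step at the edge of the scatter rather than a large one. Compound 4 is therefore expected to give about 3.9 in this assay, most likely between 3.5 and 4.3.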

Compound 4, distribution coefficient: 4.03
Compound 4: middle estimate off by 0.13 log units, on the low side, within the range that was stated.
By their numbers in this assay, from the lowest: compounds 3, 2, 4 and 1 (each within the scatter of the next, the first and the last beyond it).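

In this assay, putting 6-fluoro-2,3-dihydro-1H-inden-1-yl in place of 2,4-difluorophenyl on the sulfonamide nitrogen gives a number 0.41 log units higher from compound 3 to compound 4 (beyond the scatter). Within the data shown here, this is the first step here in which only one place changes, with the saturated chain carbon and the sulfonyl sulfur on that nitrogen staying the same, so it shows that a change at this position alone can move the number by more than the usual scatter. The entering group has 10 heavy atoms against 8, one fluorine instead of two and an added five-membered non-aromatic ring, but nothing measured here ties the rise to any one of these differences.

From the compounds shown here alone, with a single step at this position, the effect of a quite different group there, such as an amine, a carboxylic acid or a longer chain, remains open. Also open, going by these compounds, is how 2,3-dihydro-1H-inden-1-yl without its fluorine would read in this assay, a comparison that would separate the added ring from the change in fluorine count.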